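A few compounds are considered here, and "the series" means these few. Any claim that something is new, unique, unknown or untested is made for them only; others in the source may bear on it.

Going by the values given here, in a physicochemical assay for lipophilicity, at pH 7.4 (on this read-out lower numbers stand for lower lipophilicity and higher numbers for higher lipophilicity), compound 1 `CCc1ccc(N(CC2CCC2)S(=O)(=O)c2ccc3c(c2)C(=O)CC(C2CCOCC2)O3)cc1` gives 4.1 and compound 2 `CCc1ccc(N(CC2CC2)S(=O)(=O)c2ccc3c(c2)C(=O)CC(C2CCOCC2)O3)cc1` gives 3.77, the lower of the two numbers so far. Compound 3 `CCc1ccc(N(Cc2ccccc2)S(=O)(=O)c2ccc3c(c2)C(=O)CC(C2CCOCC2)O3)cc1` follows from compound 2 by this change: phenyl in place of cyclopropyl on a saturated chain carbon bound to a sulfonamide nitrogen. Phenyl takes the place of cyclopropyl on a saturated chain carbon bound to a sulfonamide nitrogen. Among the compounds with values here, the only measured step bearing on this place is a number 0.33 log units lower from compound 1 to compound 2 (beyond the scatter), a modest one, in which the ring with fewer carbons gave the lower number. On that single precedent, a modest rise beyond the scatter is expected in this assay, as a number 0.43 log units higher from compound 2 to compound 3 (beyond the scatter). For compound 3 the estimate is 4.2, with an expected range of 3.85 to 4.6.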

Compound 3, distribution coefficient: 4.84
Compound 3: middle estimate off by 0.64 log units, on the low side, outside the stated range (above it).
By their numbers in this assay, from the lowest: compound 2; then compound 1; then compound 3.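

In this assay, phenyl in place of cyclopropyl on a saturated chain carbon bound to a sulfonamide nitrogen gives a number 1.07 log units higher from compound 2 to compound 3 (beyond the scatter), and phenyl in place of cyclobutyl gives a number 0.74 log units higher from compound 1 to compound 3 (beyond the scatter). Both steps are larger than the change between the two saturated rings, a number 0.33 log units lower from compound 1 to compound 2 (beyond the scatter), so at this position the read-out responds more to the exchange for phenyl than to the ring-size change seen earlier. Nothing available explains the size of these steps.

From the compounds shown here alone, it remains open whether an amine, a carboxylic acid or a longer chain at this place would give a number below that of compound 2.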